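This account rests on a few compounds, and the source may have more. Where it says the series, first, only, none or still open, it means among the compounds named here.

Compound 1 `CCOC(=O)NC/C=C\CN(C)C[C@H]1O[C@@H](n2c(C)nc3c(N)ncnc32)[C@H](O)[C@@H]1O` gives > 1.5 h.
Compound 2 `Cc1nc2c(N)ncnc2n1[C@@H]1O[C@H](CN(C)C/C=C\CNC(=O)OC(C)C)[C@@H](O)[C@H]1O` gives > 1.5 h.
Compound 3 `CCC(=O)NC/C=C\CN(C)C[C@H]1O[C@@H](n2cnc3c(N)ncnc32)[C@H](OC(C)=O)[C@@H]1OC(C)=O` gives 1.25 h.

All three were run in an ADME assay on microsomes from liver (Homo sapiens) for metabolic stability, read by LC-MS, using NADPH, tested at 1 uM; on this read-out higher numbers stand for a longer-lived compound and lower numbers for a shorter-lived compound. For compound 1 the value > 1.5 h is a limit of the assay, not a number. For compound 2 the value > 1.5 h is likewise a limit. Compound 3, with 1.25 h, is the only one of the three with a number in this assay.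

Compound 1 and compound 2 share a core and differ by one change: methyl in place of hydrogen on a saturated chain carbon bound to an oxygen next to a carbonyl group and a saturated chain carbon. The step that the two limits leave unreadable from compound 1 to compound 2 cannot be read, because the limit of > 1.5 h in this assay, at which 2 of the 3 values shown sit, hides any difference between the two.

The difference between the core of compound 1 and the core of compound 3 is not broken down here.

Compound 4 `CCCC(=O)NC/C=C\CN(C)C[C@H]1O[C@@H](n2cnc3c(N)ncnc32)[C@H](OC(C)=O)[C@@H]1OC(C)=O` has not yet been measured. It differs from compound 3 by methyl in place of hydrogen on a saturated chain carbon, two bonds along the chain from a carbonyl carbon. This is the same kind of change as that from compound 1 to compound 2, but not the same: in the earlier pair the place is a saturated chain carbon bound to an oxygen next to a carbonyl group and a saturated chain carbon, whereas here the place is a saturated chain carbon, two bonds along the chain from a carbonyl carbon.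

The earlier step sets no readable size, so the expected step of a 1.1-fold lower number from compound 3 to compound 4 (0.06 log units; within the scatter) for compound 4 in this assay rests on the value of compound 3, 1.25 h, and on the small size of the added methyl. For compound 4 the half-life in this assay is estimated at 1.1 h, within a range of 0.6 h to 1.5 h.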

Compound 4, half-life: 0.85 h
Beside the measured number, compound 4's estimate is 1.3-fold (0.11 log units) above it; measured number inside the range.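

In this assay the added methyl gives a 1.5-fold lower number from compound 3 to compound 4 (0.17 log units; within the scatter), and this step lies within the usual scatter of repeated measurements, so on this core the change cannot be told apart from no change at all. The same kind of change, at a different place on the core of compound 1, gives a step that cannot be read, which leaves no second size to set against this one: the limit of > 1.5 h in this assay, at which 2 of the 4 values shown sit. The series therefore shows one readable step on one core and does not show whether a methyl keeps that size when it is carried to another core, though nothing here speaks against it either.

The compounds shown leave open how this assay would read with a longer chain than propylcarbonyl, or with an amine or a carboxylic acid on the saturated chain carbon, two bonds along the chain from a carbonyl carbon. Also open, going by these compounds, is how the same methyl would read on a core whose compounds give numbers rather than limits, which is what a real comparison between two cores would need.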